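The source may report more compounds than this note shows. Statements on the series, on what has been measured and on what is new or still open speak of the compounds shown alone.

Measured compounds:
compound 1, `O=C(NCCCOc1ccc2[nH]c(=O)ccc2c1)N(C1CC1)[C@@H]1CCCC[C@H]1O`, gives 24%; 29% (2 entries) in a functional assay on the whole organism for inhibition, with Rattus norvegicus as the target, at a dose of 30 mg/kg by the oral route; on this read-out lower numbers stand for less inhibition and higher numbers for more inhibition at the one dose given (going by the name of the read-out)
compound 2, `O=C(NCCCOc1ccc2nc(O)ccc2c1)N(C1CC1)[C@@H]1CCCCC[C@H]1O`, gives 0% in this assay
compound 3, `O=C(NCCCOc1ccc2nc(O)ccc2c1)N(C1CCCCC1)[C@H]1CCCC[C@@H]1O`, gives 18% in this assay

Compound 2 stands lowest of the two compounds that have a single number in this assay. Its nearest neighbour, compound 3, sits a step higher that lies beyond the usual scatter of repeated measurements. Compound 1 has two entries rather than a single number (the several entries of compound 1 in this assay, 24%; 29% (2 entries)), and both of them lie above the value of compound 2.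

Compound 4, `O=C(NCCCOc1ccc2nc(O)ccc2c1)N(C1CC1)[C@H]1CC[C@H](O)CC1`, has not yet been measured in this assay. It differs from compound 2 in one place: 4-hydroxycyclohexyl in place of 2-hydroxycycloheptyl on an amide-type nitrogen. Among the compounds with values here, no step between measured compounds mirrors this change, so the expectation rests on the low value of compound 2 and the higher readings of compound 1 and compound 3. The step in this assay from compound 2 to compound 4 is expected to be a small rise, a number 10 percentage points higher from compound 2 to compound 4 (within the scatter), possibly still within the scatter. Compound 4 is therefore estimated at 10%, with a likely range from 0% to 30%.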

Compound 4, a percentage reported as inhibition, in the whole organism at one dose (the size of the read-out at that dose, not a potency): 7%
Compound 4: middle estimate off by 3 percentage points, on the high side; measured number inside the range.
By their numbers in this assay, from the lowest: compounds 2 and 4 (each within the scatter of the next); then compound 3.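

In this assay, replacing 2-hydroxycycloheptyl with 4-hydroxycyclohexyl on the amide-type nitrogen gives a number 7 percentage points higher from compound 2 to compound 4 (within the scatter). Within the data shown here, this is the first direct comparison in this set between two compounds that differ in one place, and it shows that this change, which alters both the ring size and the name of the hydroxy-bearing ring, does not separate the two compounds on this read-out. No measurement shown here explains why the two compounds cannot be told apart.

The compounds shown leave open whether an amine or a carboxylic acid in place of the hydroxy group on this ring would give a different number at this position. With only one dose shown, they also leave open how compound 2 and compound 4 would compare at other doses.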